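The source may report more compounds than this note shows. Statements on the series, on what has been measured and on what is new or still open speak of the compounds shown alone.

In a functional assay on NCI-H460 cells (Homo sapiens) for inhibition, read by sulforhodamine B assay, with a stated time of 72 h (a higher number here means a weaker inhibitor, a lower number a stronger inhibitor), compound 1 `CC(C)c1cc(-n2cc(-c3ccc(CN4CCN(c5ccccc5)CC4)cc3)nn2)c(O)cc1O` gives > 1000 nM, which is a limit of the assay and not a number. Compound 2 `CC(C)c1cc(-n2nncc2-c2ccc(CN3CCN(c4ccccc4)CC3)cc2)c(O)cc1O` gives 520 nM. Compound 3 `CCNC(=O)c1nnn(-c2cc(C(C)C)c(O)cc2O)c1-c1ccc(CN2CCC[C@H](O)C2)cc1` gives 70 nM, the lowest number shown, and its gap to compound 2, the nearest value, lies beyond the scatter. Compound 4 `CCNC(=O)c1nnn(-c2cc(C(C)C)c(O)cc2O)c1-c1ccc(CN2CCC[C@@H](O)C2)cc1` is still to be measured. Its structure departs from compound 3 as follows: the two compounds have the same atoms and bonds and differ only in configuration as drawn: 1 of 1 stereo elements differ; a stereocentre at a saturated ring carbon is drawn S in compound 3 and R in compound 4. Going by the values given here, no measured pair shows the effect of such a change, so no direction is favoured, and a step in this assay no larger than the scatter is expected. The expected change is a 1.1-fold higher number from compound 3 to compound 4 (0.06 log units; within the scatter). Compound 4 is estimated at 80 nM, with an expected range of 30 nM to 220 nM.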

Compound 4, half-maximal inhibitory concentration: 52 nM
The estimate for compound 4 lay 1.5-fold (0.19 log units) above the measured number; the measured number falls inside the stated range.
By their numbers in this assay, from the lowest: compounds 4 and 3 (each within the scatter of the next); then compound 2. At a limit, above all of these: compound 1.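

In this assay, going by these compounds alone, the stereocentre at the saturated ring carbon can be read directly for the first time, and going from S to R gives a 1.3-fold lower number from compound 3 to compound 4 (0.13 log units; within the scatter). In this assay, the drawn configuration at this carbon does not separate the two compounds. No other structural change enters this comparison: the fact that compounds 3 and 4 differ only in the configuration as drawn.

The compounds shown leave open what an amine or a carboxylic acid in place of the hydroxyl would do at this ring carbon. As far as these compounds go, whether the same inversion stays within the scatter alongside a longer chain on the amide also remains open.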